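A few compounds are considered here, and "the series" means these few. Any claim that something is new, unique, unknown or untested is made for them only; others in the source may bear on it.

Working notes on the sulfonyl series, read in a functional assay (Cavia porcellus) with sulfonylurea receptors; K-ATP channels (Homo sapiens) as the target; on this read-out higher numbers stand for weaker inhibition and lower numbers for stronger inhibition. Compound 1 `CC(O)(C(=O)Nc1ccc(S(=O)(=O)c2ccccc2O)cc1)C(F)(F)F` gives 3090 nM in this assay. Compound 2 `COc1ccc(S(=O)(=O)c2ccc(NC(=O)C(C)(O)C(F)(F)F)cc2)cc1` reaches only the limit of this assay, > 30000 nM, and that limit is noted as the limit of > 30000 nM in this assay, at which 1 of the 3 values shown sits. Compound 3 `Cc1cccc(S(=O)(=O)c2ccc(NC(=O)C(C)(O)C(F)(F)F)cc2)c1` gives 2200 nM in this assay; of the two numbers it is the lowest, compound 1 being nearest with a gap of a 1.4-fold lower number from compound 1 to compound 3 (0.15 log units; within the scatter). The group on the sulfonyl sulfur is the only place varied: the step of an at least 9.7-fold higher number from compound 1 to compound 2 (0.98 log units; beyond the scatter) and the step of an at least 13-fold lower number from compound 2 to compound 3 (1.13 log units; beyond the scatter) show that one ring substituent can push the number past the limit, while the other two rings sit close together.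

Compound 4 `CC(O)(C(=O)Nc1ccc(S(=O)(=O)c2ccccn2)cc1)C(F)(F)F` is the next member; it differs by pyridin-2-yl in place of 3-methylphenyl on a sulfonyl sulfur. Among the compounds with values here, no measured step exchanges a carbon-only ring for one carrying a ring nitrogen, so the direction rests on the spread of compounds 1, 2 and 3 alone. A step of a 2.3-fold higher number from compound 3 to compound 4 (0.36 log units; beyond the scatter) is expected, toward a somewhat higher number, since compound 2 shows the sulfonyl ring can lose activity entirely, while compound 1 shows an acceptor-bearing ring can be kept. Compound 4 is therefore estimated at 5000 nM, within 1500 nM to 20000 nM.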

Compound 4, half-maximal inhibitory concentration: 600 nM
Beside the measured number, compound 4's estimate is 8.3-fold (0.92 log units) above it; the whole stated range lies above it.
By their numbers in this assay, from the lowest: compound 4; then compounds 3 and 1 (each within the scatter of the next). At a limit, above all of these: compound 2.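

In this assay, the position proves able to do more than hold the number near that of the carbon-only rings: pyridin-2-yl on the sulfonyl sulfur gives the lowest number of the series, with a 3.7-fold lower number from compound 3 to compound 4 (0.56 log units; beyond the scatter) and a 5.2-fold lower number from compound 1 to compound 4 (0.71 log units; beyond the scatter). The ring that leaves compound 2 out of range and the ring of compound 4 are now far apart, with an at least 50-fold lower number from compound 2 to compound 4 (1.69 log units; beyond the scatter). That step is only a bound, since the value of compound 2 is a limit: the limit of > 30000 nM in this assay, at which 1 of the 4 values shown sits.

Open remains whether the gain belongs to the ring nitrogen itself or to the loss of the other rings' substituents, a question that plain phenyl on the sulfonyl sulfur would address. Pyridin-3-yl, pyridin-4-yl or pyrimidin-2-yl would show whether the place and number of ring nitrogens matter.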